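A few compounds are considered here, and "the series" means these few. Any claim that something is new, unique, unknown or untested is made for them only; others in the source may bear on it.

Compound 1 `CNC(=O)[C@@H]1CC[C@H](c2ccc(OCc3ccccc3F)cc2)N1`: in an assay on HEK293 cells for inhibition of sodium channel protein type 3 subunit alpha (Homo sapiens), read by electrophysiology, with a stated time of 3.5 min (a higher number here means a weaker inhibitor, a lower number a stronger inhibitor), this compound gives only a limit, > 63000 nM.
Compound 2 `C[C@@H](C(N)=O)N1CCc2cc(OCc3ccccc3F)ccc2C1`: in this assay compound 2 likewise gives only a limit, > 79400 nM.
Compound 3 `N#Cc1ccccc1COc1ccc([C@H]2CC[C@@H](C(N)=O)N2)cc1`: in this assay compound 3 gives only a limit, > 63000 nM.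

Compound 3 therefore stands at a limit of this assay rather than at a number, and the two other values shown are limits as well. Two of the three values sit at the limit of > 63000 nM in this assay, at which 2 of the 3 values shown sit, and one sits at the limit of > 79400 nM in this assay, at which 1 of the 3 values shown sits. Among the compounds with values here, none of the three compounds shows measurable inhibition, and no step between measured compounds can be drawn from them.

Compound 4 `NC(=O)[C@@H]1CC[C@H](c2ccc(OCc3ccc(F)cc3)cc2)N1` differs from compound 3 in one place: 4-fluorophenyl in place of 2-cyanophenyl on a saturated chain carbon bound to an oxygen on an aromatic ring. Compound 1 carries a fluorophenyl group at the same place and gives a limit, and compound 3 with the cyanophenyl group gives a limit, so the exchange is expected to move nothing beyond the scatter. The step from compound 3 to compound 4 is expected to be a step that the limit leaves unreadable from compound 3 to compound 4, most likely with this assay again reporting a limit rather than a number. For compound 4 in this assay the estimate is 80000 nM, in a range from 30000 nM to 300000 nM.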

Compound 4, half-maximal inhibitory concentration: > 63000 nM
Compound 4 ended at the assay's limit (the forecaster's own chance of this, stated with the estimate: 85%); the middle value is on the limit's open side.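

In this assay compound 4 gives only a limit, > 63000 nM. Compound 3 likewise gives only a limit, > 63000 nM. No step can be read from compound 3 to compound 4, with 4-fluorophenyl in place of 2-cyanophenyl. The compounds shown leave open what structure, if any, would give a measured number in this assay.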